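Benzyloxy variation in the cyclopentene acid series

The source may report more compounds than this note shows. Statements on the series, on what has been measured and on what is new or still open speak of the compounds shown alone.

Compound 2 `CSc1ccc(OCc2ccc(F)cc2F)c(C2=C(c3cccc(C(=O)O)c3)CCC2)c1`, which carries methylsulfanyl on the aromatic carbon where compound 1 `O=C(O)c1cccc(C2=C(c3cc(Br)ccc3OCc3ccc(F)cc3F)CCC2)c1` carries bromo, sits at the higher end of the two numbers in hand: in an assay on isolated protein for inhibition of prostaglandin E2 receptor EP1 subtype (Homo sapiens) (on this read-out higher numbers stand for weaker inhibition and lower numbers for stronger inhibition), compound 2 gives 15.9 nM, while compound 1 gives 5.01 nM. Among the measured compounds shown here, the one measured step, a 3.2-fold higher number from compound 1 to compound 2 (0.50 log units; beyond the scatter), concerns the aromatic substituent and not the benzyloxy side, so it does not bear directly on the next change. Compound 3 `CSc1ccc(OCc2ccccc2)c(C2=C(c3cccc(C(=O)O)c3)CCC2)c1` differs from compound 2 by phenyl in place of 2,4-difluorophenyl on a saturated chain carbon bound to an oxygen on an aromatic ring. For the measured compounds named here, no measured pair in this set changes that part, so the expectation rests on the change itself and the general scale of the series. A step of modest size toward a higher number, or none beyond the scatter, is expected, a 1.6-fold higher number from compound 2 to compound 3 (0.20 log units; within the scatter). Compound 3 is estimated at 25 nM, with a range from 8 nM to 80 nM.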

Compound 3, half-maximal inhibitory concentration: 63.1 nM
The estimate for compound 3 lay 2.5-fold (0.40 log units) below the measured number, and the stated range covers the measured number.
By their numbers in this assay, from the lowest: compound 1; then compound 2; then compound 3.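

In this assay the change from 2,4-difluorobenzyl to benzyl brings a 4.0-fold higher number from compound 2 to compound 3 (0.60 log units; beyond the scatter) and so shows that this part of the molecule, untouched by the earlier pair, registers on this read-out. With methylsulfanyl held in place, the 2,4-difluorophenyl group goes with the lower number and the phenyl group with the higher, a finding that rests on this single pair. Nothing available here accounts for the step.

Open, going by these compounds, is whether one fluorine would carry the step or both are needed, and how a benzyl group bearing a single fluorine, a chlorobenzyl group or a longer chain such as phenethyl would read at this place. Also open, on these data alone, is whether the same change would give a similar step with bromo in place of methylsulfanyl on the aromatic carbon.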